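The source may report more compounds than this note shows. Statements on the series, on what has been measured and on what is new or still open speak of the compounds shown alone.

Working notes on the series in a functional assay on CHO cells for agonist activity at prostaglandin E2 receptor EP2 subtype (Homo sapiens), read by HTRF and cAMP accumulation, with a stated time of 30 min; a lower number here means that less compound is needed, a higher number that more compound is needed for the effect.

For the measured compounds named here, compound 1 `O=C(O)c1csc([C@H]2CC[C@@H]3[C@@H](COc4ccc(C(F)(F)F)cc4)[C@H](O)C[C@@H]3O2)n1` gives 13 nM in this assay, which puts it second highest of the three numbers measured so far. Its nearest neighbour is compound 2 `O=C(O)c1csc([C@H]2CC[C@@H]3[C@@H](COc4ccc(OC(F)(F)F)cc4)[C@H](O)C[C@@H]3O2)n1`, which gives 14 nM; the step of a 1.1-fold higher number from compound 1 to compound 2 (0.03 log units; within the scatter) stays within the scatter. Going by the values given here, the furthest is compound 3 `O=C(O)c1csc([C@H]2CC[C@@H]3[C@@H](COc4cccc(F)c4)[C@H](O)C[C@@H]3O2)n1`, which gives 5.4 nM; the step of a 2.4-fold lower number from compound 1 to compound 3 (0.38 log units; beyond the scatter) is the only change in the set that moved the number beyond the scatter.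

Compound 4 `O=C(O)c1csc([C@H]2CC[C@@H]3[C@@H](COc4ccc(F)cc4)[C@H](O)C[C@@H]3O2)n1` is the next point to measure. Relative to compound 1 the change is fluoro in place of trifluoromethyl on an aromatic carbon. Among the compounds with values here, two measured steps bear on it. Swapping trifluoromethyl for trifluoroxymethoxy, as in the step from compound 1 to compound 2, left the number unchanged within the scatter. Replacing the whole 4-(trifluoromethyl)phenyl by 3-fluorophenyl, the step to compound 3, gave a modest lower number. The present change, keeping the phenyl but trading trifluoromethyl for a single fluoro, is expected to fall between those two outcomes: a small lower number, or none beyond the scatter.

For compound 4 the estimate in this assay is 8 nM, with a range from 4 nM to 16 nM, corresponding to an expected step of a 1.6-fold lower number from compound 1 to compound 4 (0.21 log units; within the scatter).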

Compound 4, half-maximal effective concentration: 7 nM
Compound 4: the middle estimate sits 1.1-fold (0.06 log units) above what was measured, and the stated range covers the measured number.
By their numbers in this assay, from the lowest: compounds 3, 4, 1 and 2 (each within the scatter of the next, the first and the last beyond it).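

Working from this assay, fluoro in place of trifluoromethyl on this aromatic carbon gives a 1.9-fold lower number from compound 1 to compound 4 (0.27 log units; within the scatter) and fluoro in place of trifluoromethoxy gives a 2.0-fold lower number from compound 2 to compound 4 (0.30 log units; within the scatter) so neither swap moves the number beyond the scatter, and a single fluorine at this place serves about as well as either of the two larger fluorinated groups. For the compounds shown here, the fluorophenyl comparison, with 4-fluorophenyl in place of 3-fluorophenyl, gives a 1.3-fold higher number from compound 3 to compound 4 (0.11 log units; within the scatter) and so does not separate the two fluorine placements, while compound 4 stays within the scatter of both compound 1 and compound 3, leaving the one step beyond the scatter in this set without a single identifiable contributor. Nothing available explains these steps.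

Still open is whether an amine, a nitrile or a longer alkoxy chain on this aromatic carbon would move the number beyond the scatter, since all the substituents shown here carry fluorine. The compounds also leave open how a plain unsubstituted phenyl would compare with the fluorinated ones, and whether a primary amide could stand in for the carboxylic acid on the shared core.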